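The source may report more compounds than this note shows. Statements on the series, on what has been measured and on what is new or still open speak of the compounds shown alone.

Within the data shown here, compound 2 `Nc1ncnn2c([C@@H]3O[C@H](CO)[C@@H](O)[C@H]3O)cc(-c3ccccc3)c12` gives 65200 nM in a functional assay on CAPAN-1 cells (Homo sapiens) for antiproliferative activity, with a stated time of 72 h (a lower number here means a stronger inhibitor, a higher number a weaker inhibitor), the higher of the two numbers known so far. Compound 1 `Nc1ncnn2c([C@@H]3O[C@H](CO)[C@@H](O)[C@H]3O)cc(C#CC3CC3)c12` gives 20 nM in this assay, and the step of a 3300-fold higher number from compound 1 to compound 2 (3.51 log units; beyond the scatter) separates them. Compound 3 `Nc1ncnn2c([C@@H]3O[C@H](CO)[C@@H](O)[C@H]3O)cc(-c3ccccc3F)c12` differs from compound 2 by fluoro in place of hydrogen on an aromatic carbon. Among the measured compounds shown here, no measured step concerns a fluoro group, so nothing among the measured compounds speaks for a step beyond the scatter in this assay in either direction. Compound 3 is therefore expected to give 50000 nM (range 15000 nM to 200000 nM), a step of a 1.3-fold lower number from compound 2 to compound 3 (0.12 log units; within the scatter) that is expected to stay within the scatter.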

Compound 3, half-maximal inhibitory concentration: > 100000 nM
Compound 3: a limit, no number; the forecaster's own chance of this, stated with the estimate: 15%; middle value at least 2.0-fold (0.30 log units) from the limit.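

For compound 3 the read-out is a limit of the assay, not a number: the limit of > 100000 nM in this assay, at which 1 of the 3 values shown sits. Fluoro on an aromatic carbon, ortho to a large group, gives an at least 1.5-fold higher number from compound 2 to compound 3 (0.18 log units; that floor lies within the scatter), so adding it brings no lower number, though that floor shows no real change either. Placing 2-fluorophenyl instead of 2-cyclopropylethynyl gives an at least 5000-fold higher number from compound 1 to compound 3 (3.69 log units; beyond the scatter), so the large gap first seen with phenyl also holds for this second aromatic group. As far as these compounds go, whether fluoro changes the number at all stays open. Also open, from the compounds shown here alone, is whether an amine or methoxy group on that aromatic ring, or a longer alkyne chain, would give a low number.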